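The source may report more compounds than this note shows. Statements on the series, on what has been measured and on what is new or still open speak of the compounds shown alone.

Compound 1 `CCN(CC)C(=S)SCC1=CCOC1=O` gives 1390 nM in a functional assay on HeLa cells (Homo sapiens) for antiproliferative activity, read by MTT assay, with a stated time of 72 h; a lower number here means a stronger inhibitor, a higher number a weaker inhibitor. Compound 2 `O=C1OCC=C1CSC(=S)NC1CC1` gives 24100 nM in this assay.

On these two numbers compound 2 stands highest; its nearest neighbour is compound 1, and the step between them is a 17-fold higher number from compound 1 to compound 2 (1.24 log units; beyond the scatter), a large step and beyond the scatter. Compound 3 `CN(C)C(=S)SCC1=CCOC1=O` differs from compound 2 by dimethylamino in place of cyclopropylamino on a thiocarbonyl carbon. Going by the values given here, the one measured step that bears on this change is a 17-fold higher number from compound 1 to compound 2 (1.24 log units; beyond the scatter), where diethylamino gave way to cyclopropylamino on the same thiocarbonyl carbon and the number rose sharply. Compound 3 reverses that kind of exchange, returning from cyclopropylamino to a dialkylamino group that, like diethylamino, carries no hydrogen-bond donor. A step downward in this assay of roughly the size seen from compound 1 to compound 2 is therefore expected, though dimethylamino is not diethylamino, so the estimate is held wide. Compound 3 is expected at 2000 nM (range 700 nM to 6000 nM), a step of a 12-fold lower number from compound 2 to compound 3 (1.08 log units; beyond the scatter).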

Compound 3, half-maximal inhibitory concentration: 114000 nM
Estimate against measurement, compound 3: 57-fold (1.76 log units) below, outside the stated range (above it).
By their numbers in this assay, from the lowest: compound 1; then compound 2; then compound 3.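

In this assay, dimethylamino in place of cyclopropylamino gives a 4.7-fold higher number from compound 2 to compound 3 (0.67 log units; beyond the scatter) and so moves the number up, even though the group that enters has no hydrogen-bond donor and the group that leaves has one. Diethylamino and dimethylamino both lack a donor, yet they are separated by an 82-fold higher number from compound 1 to compound 3 (1.91 log units; beyond the scatter) and lie at opposite ends of the series, so the presence or absence of a donor on this thiocarbonyl carbon does not by itself set the order of these compounds. Nothing shown here gives a reason for this order.

From the compounds shown here alone, with only these three amino groups, it remains open whether a longer chain such as dipropylamino would follow diethylamino. The effect of a ring amine such as piperidine or morpholine at this place is equally unsettled.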